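Chloro on the Fused Ring: Expecting the Next Value

A few compounds are considered here, and "the series" means these few. Any claim that something is new, unique, unknown or untested is made for them only; others in the source may bear on it.

Measured compounds:
compound 1, `Cc1cnc(Nc2ccc(S(C)(=O)=O)cc2)nc1Nc1nc2ccc(Cl)cc2s1`, 13400 nM
compound 2, `CS(=O)(=O)c1ccc(Nc2nccc(Nc3nc4ccccc4s3)n2)cc1`, 1710 nM

In a functional assay on PC-3 cells (Homo sapiens) for antiproliferative activity, read by MTT assay, with a stated time of 48 h (on this read-out higher numbers stand for weaker inhibition and lower numbers for stronger inhibition), compound 2 gives 1710 nM, the lower of the two numbers, and compound 1 gives 13400 nM, a gap beyond the scatter. Compound 3, `CS(=O)(=O)c1ccc(Nc2nccc(Nc3nc4ccc(Cl)cc4s3)n2)cc1`, differs from compound 2 by chloro in place of hydrogen on an aromatic carbon. Within the data shown here, no measured pair shows this single change on its own, so the expected step is small, likely not beyond the scatter, with a slight lean toward a higher number. For compound 3 the expected value in this assay is 2500 nM, with a range from 800 nM to 8000 nM, meaning an estimated step of a 1.5-fold higher number from compound 2 to compound 3 (0.16 log units; within the scatter).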

Compound 3, half-maximal inhibitory concentration: > 50000 nM
Compound 3 gave a limit, no number; the forecaster's own chance of this, stated with the estimate: 3%; middle value at least 20-fold (1.30 log units) from the limit.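

Compound 3 reaches a limit of the assay, not a number, in this assay: the limit of > 50000 nM in this assay, at which 1 of the 3 values shown sits.

Chloro in place of hydrogen on the six-membered aromatic ring of carbon only brings an at least 29-fold higher number from compound 2 to compound 3 (1.46 log units; beyond the scatter), so this one position is far from indifferent to change. With chloro in place, hydrogen in place of methyl brings an at least 3.7-fold higher number from compound 1 to compound 3 (0.57 log units; beyond the scatter), so the methyl place matters as well.

Still open, going by these compounds, is whether the loss belongs to chloro itself or would also follow from an amine or a methoxy group at this position. Other carbons of that ring also remain open.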